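Dichloro Versus Monochloro Purines in a Kidney Cell Toxicity Test

The compounds below may be only part of what the source reports. "The series", "measured", "known", "first", "only" and "open" are said of these compounds alone.

Compound 1 `ClCc1cccc(Cn2cnc3c(Cl)ncnc32)c1` gives 58900 nM in a functional assay on A498 cells (Homo sapiens) for cytotoxicity, read by sulforhodamine B assay, with a stated time of 48 h; on this read-out lower numbers stand for higher toxicity in this test and higher numbers for lower toxicity in this test.
Compound 2 `ClCc1cccc(Cn2cnc3c(Cl)nc(Cl)nc32)c1` gives 27500 nM.
Compound 3 `ClCc1ccccc1Cn1cnc2ncnc(Cl)c21` gives 57500 nM.

Within the data shown here, the only single-point step among the measured compounds runs from compound 1 to compound 2, a change of chloro in place of hydrogen on an aromatic carbon. That step gave a 2.1-fold lower number from compound 1 to compound 2 (0.33 log units; beyond the scatter). Compound 1 and compound 3 are built from the same atoms joined differently; the difference between the two cores is not broken down here, and their two values lie close together, within the usual scatter of this assay.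

Compound 4 `ClCc1ccccc1Cn1cnc2nc(Cl)nc(Cl)c21` has not yet been measured. Among the measured compounds shown here, it differs from compound 3 by chloro in place of hydrogen on an aromatic carbon, which is the same change as the one made from compound 1 to compound 2, at a place described in identical terms. On that basis, compound 4 is expected to show a step of a 2.1-fold lower number from compound 3 to compound 4 (0.31 log units; beyond the scatter), resting on the measured result of a 2.1-fold lower number from compound 1 to compound 2 (0.33 log units; beyond the scatter) applied to the value of compound 3, 57500 nM. Compound 4 is therefore estimated at 28000 nM, with a likely range from 14000 nM to 57000 nM.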

Compound 4, concentration lethal to 50% of the cells: 19500 nM
The estimate for compound 4 lay 1.4-fold (0.16 log units) above the measured number; the range from low to high includes it.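

Chloro in place of hydrogen on an aromatic carbon, between two ring nitrogen atoms, gave a 2.9-fold lower number from compound 3 to compound 4 (0.47 log units; beyond the scatter) in this assay. Set beside the earlier case, the change carried from one core to the other with a step of much the same size and in the same direction: the same change on two cores in this assay, a 2.1-fold lower number (0.33 log units; beyond the scatter) from compound 1 to compound 2 and a 2.9-fold lower number (0.47 log units; beyond the scatter) from compound 3 to compound 4, 1.4-fold (0.14 log units) apart, within the scatter of two such steps. This supports carrying the change across these two cores in this one cell test, but two pairs cannot show that it would hold on any other core, and they do not show why the number drops.

The compounds shown leave open whether an amine or a methoxy group in place of the chloro between two ring nitrogen atoms would move the number in the same way. They also leave open what happens to these values when the chloromethyl group gives way to a plain methyl or a hydroxymethyl group.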